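Swapping the Aromatic Amide Cap in a Pancreatic Cell Assay

The compounds below may be only part of what the source reports. "The series", "measured", "known", "first", "only" and "open" are said of these compounds alone.

Measured in a functional assay on PANC-1 cells (Homo sapiens) for inhibition, read by MTT assay, with a stated time of 24 h, tested at 10 uM; a lower number here means less inhibition, a higher number more inhibition at the concentration tested (going by the name of the read-out):
compound 1 `CC(C)=CCC/C(C)=C/COc1cc(=O)n(CCCO)c2c1CC(CC=C(C)C)C(C)(C)C2` gives 10.6%
compound 2 `COc1ccc(C(=O)NCCCOc2cc(=O)n(CCCO)c3c2CC(CC=C(C)C)C(C)(C)C3)cc1` gives 55.5%

Compound 2 stands highest of the two numbers in this assay; its nearest neighbour, compound 1, lies lower by a gap that is beyond the usual scatter. Within the data shown here, the two differ in more than one place, so no single step can be drawn from them.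

Compound 3 `CC(C)=CCC1Cc2c(OCCCNC(=O)c3ccco3)cc(=O)n(CCCO)c2CC1(C)C` has not yet been measured. Compared with compound 2 it carries one change: furan-2-yl in place of 4-methoxyphenyl on a carbonyl carbon.

Among the measured compounds shown here, no step between two measured compounds is available to calibrate this kind of change, so the expectation rests on compound 2 alone. The step of a number 15.5 percentage points lower from compound 2 to compound 3 (beyond the scatter) is expected to be a moderate decrease, somewhat beyond the scatter, since the amide linker that separates compound 2 from compound 1 is kept. Compound 3 is therefore estimated at 40%, with a range from 15% to 65%.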

Compound 3, a percentage reported as inhibition, at one concentration (the size of the read-out at that concentration, not a potency): 2.1%
Estimate against measurement, compound 3: 37.9 percentage points above, and the stated range ends above it.
By their numbers in this assay, from the lowest: compounds 3 and 1 (each within the scatter of the next); then compound 2.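

In this assay, the group on the carbonyl carbon turns out to matter a great deal: furan-2-yl in place of 4-methoxyphenyl gives a number 53.4 percentage points lower from compound 2 to compound 3 (beyond the scatter), a large step from a single change. The amide-bearing chain alone therefore does not secure inhibition at the concentration tested, as 2-(((furan-2-yl)carbonyl)amino)ethyl in place of 2,6-dimethylhepta-1,5-dien-1-yl gives a number 8.5 percentage points lower from compound 1 to compound 3 (within the scatter). No measurement is at hand that explains this loss.

The change replaces a six-membered ring with a five-membered one and also removes the methoxy group, and the compounds shown cannot separate these two differences. A plain phenyl group or a 4-hydroxyphenyl group on the same carbonyl carbon would show whether the ring itself or its methoxy group goes with the higher number.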